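The compounds below may be only part of what the source reports. "The series", "measured", "known", "first", "only" and "open" are said of these compounds alone.

Going by the values given here, in a functional assay on PC-9 cells (Homo sapiens) for inhibition, read by MTT assay, with a stated time of 48 h, tested at 10 uM (on this read-out lower numbers stand for less inhibition and higher numbers for more inhibition at the one concentration tested (going by the name of the read-out)), compound 2 `COc1cc(NC(=O)Nc2cc(Nc3cc(Br)ccc3OC)ncn2)cc(OC)c1` gives 82.5%, the higher of the two numbers measured so far, while compound 1 `COc1cc(NC(=O)Nc2cc(Nc3cc(F)ccc3OC)ncn2)cc(OC)c1` gives 59.5%. Among the compounds with values here, the single step measured, a number 23 percentage points higher from compound 1 to compound 2 (beyond the scatter), came from swapping one halogen for a heavier one. Compound 3 `COc1cc(NC(=O)Nc2cc(Nc3ccc(OC)c(I)c3)ncn2)cc(OC)c1` differs from compound 2 in one place: 3-iodo-4-methoxyphenyl in place of 5-bromo-2-methoxyphenyl on a nitrogen on an aromatic ring. A heavier halogen again enters, but the two group names differ in more than the halogen, so that step bears on this change only loosely. A step within the usual scatter is expected, a number 6.5 percentage points lower from compound 2 to compound 3 (within the scatter). Compound 3 is therefore estimated at 76%, between 52% and 95%.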

Compound 3, a percentage reported as inhibition, at one concentration (the size of the read-out at that concentration, not a potency): 47.1%
The estimate for compound 3 lay 28.9 percentage points above the measured number; the whole stated range lies above it.
By their numbers in this assay, from the lowest: compound 3; then compound 1; then compound 2.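

The change to 3-iodo-4-methoxyphenyl on this nitrogen gave a number 35.4 percentage points lower from compound 2 to compound 3 (beyond the scatter) in this assay, and a number 12.4 percentage points lower from compound 1 to compound 3 (beyond the scatter). So the rise seen from fluoro to bromo does not carry over to every heavier halogen when the group names differ in more than the halogen. Nothing available explains this drop.

The halogen and the arrangement of the ring's groups change together here, so their shares cannot be told apart. From the compounds shown here alone, how 5-iodo-2-methoxyphenyl, which changes only the halogen, would read remains open.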